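A few compounds are considered here, and "the series" means these few. Any claim that something is new, unique, unknown or untested is made for them only; others in the source may bear on it.

Measured so far:
compound 1, `CC(=O)OC(C)n1cnc2c(S)nc(N)nc21`, 370000 nM in a functional assay on MOLT-4 cells (Homo sapiens) for inhibition; a lower number here means a stronger inhibitor, a higher number a weaker inhibitor
compound 2, `CC(=O)OCCOn1cnc2c(S)nc(N)nc21`, 8900 nM
compound 3, `CC(=O)OC(C)n1cnc2c(S)nc(F)nc21`, a limit, > 500000 nM

Three compounds carry numbers or limits here. Compound 1 gives 370000 nM in this assay. Compound 2 stands lowest of the two numbers, with 8900 nM; its nearest neighbour is compound 1, a gap beyond the usual scatter. For compound 3 the assay reports only a limit, > 500000 nM, so no number is known for it; this is the limit (the limit of > 500000 nM in this assay, at which 1 of the 3 values shown sits).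

Compound 3 differs from compound 1 in one place: fluoro in place of amino on an aromatic carbon. The step this change made is an at least 1.3-fold higher number from compound 1 to compound 3 (0.13 log units; that floor lies within the scatter), and because the measured value of compound 3 is only the limit of > 500000 nM in this assay, at which 1 of the 3 values shown sits, the true size of that step is not known.

The core of compound 2 differs from the core of compound 1, but how the two cores differ is not broken down here.

Compound 4, `CC(=O)OCCOn1cnc2c(S)nc(F)nc21`, has not yet been measured. It differs from compound 2 by fluoro in place of amino on an aromatic carbon. The place described is the same word for word as for the step from compound 1 to compound 3, so this is the same change on the second core. Compound 4 is expected to give a number higher than compound 2, a step of about a 3.4-fold higher number from compound 2 to compound 4 (0.53 log units; beyond the scatter), resting on the step of an at least 1.3-fold higher number from compound 1 to compound 3 (0.13 log units; that floor lies within the scatter), which is only a floor since compound 3 sits at a limit. The estimate for compound 4 is therefore 30000 nM, with a wide range from 8000 nM to 200000 nM.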

Compound 4, half-maximal inhibitory concentration: 35000 nM
Beside the measured number, compound 4's estimate is 1.2-fold (0.07 log units) below it; low and high end bracket the measured number.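

In this assay, fluoro in place of amino on the core of compound 2 gives a 3.9-fold higher number from compound 2 to compound 4 (0.59 log units; beyond the scatter), a step that can be read in full and that lies beyond the usual scatter. Set beside the earlier step, this shows that the change points to a higher number on both cores, but it does not show that the change has the same size on each: the same change on two cores in this assay, an at least 1.3-fold higher number (0.13 log units; that floor lies within the scatter) from compound 1 to compound 3 and a 3.9-fold higher number (0.59 log units; beyond the scatter) from compound 2 to compound 4; the limit leaves it open whether they differ Compound 3 is reported only as a limit, > 500000 nM, so the step on the core of compound 1 remains a floor, and the size of the change on that core stays unknown: the limit of > 500000 nM in this assay, at which 1 of the 4 values shown sits.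

The compounds shown leave open whether another group on that aromatic carbon, such as chloro, methoxy or a methylamino group, would follow the same course on both cores. They also leave open whether fluoro in place of amino would give a similar step on a third core, for instance one with a longer chain in the ester part, since two cores are all that is shown here.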